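The compounds below may be only part of what the source reports. "The series", "measured", "known", "first", "only" and "open" are said of these compounds alone.

Compound 1 `O=C(Nc1cccc2nonc12)N1CCN(Cc2cccc(Oc3ccc(Cl)cc3)c2)CC1`: 120 nM
Compound 2 `O=C(Nc1noc2cnccc12)N1CCN(Cc2cccc(Oc3ccc(Cl)cc3)c2)CC1`: 0.7 nM
Compound 3 `O=C(Nc1noc2ccncc12)N1CCN(Cc2cccc(Oc3ccc(Cl)cc3)c2)CC1`: 2200 nM

In an assay on isolated protein for inhibition of Fatty-acid amide hydrolase 1 (Rattus norvegicus), with a stated time of 60 min (a higher number here means a weaker inhibitor, a lower number a stronger inhibitor), compound 3 stands highest of the three numbers; its nearest neighbour is given by an 18-fold higher number from compound 1 to compound 3 (1.26 log units; beyond the scatter) and its furthest by a 3100-fold higher number from compound 2 to compound 3 (3.50 log units; beyond the scatter). Compound 4 `O=C(Nc1noc2cccnc12)N1CCN(Cc2cccc(Oc3ccc(Cl)cc3)c2)CC1` differs from compound 3 only in a group of 9 heavy atoms (6 carbon, 2 nitrogen, 1 oxygen; one five-membered aromatic ring with 2 hetero atoms, one six-membered aromatic ring with 1 hetero atom) in place of a group of 9 heavy atoms (6 carbon, 2 nitrogen, 1 oxygen; one five-membered aromatic ring with 2 hetero atoms, one six-membered aromatic ring with 1 hetero atom), on an amide-type nitrogen; the two hold the same atoms, joined differently. For the measured compounds named here, the one measured step that rearranges a ring nitrogen within this bicyclic group, a 3100-fold higher number from compound 2 to compound 3 (3.50 log units; beyond the scatter), was very large, and an 18-fold higher number from compound 1 to compound 3 (1.26 log units; beyond the scatter) was large as well, so a change of this kind is expected to move the number well beyond the scatter, though three points cannot fix its direction. Compound 4 is expected to come in lower than compound 3, with wide uncertainty: a 22-fold lower number from compound 3 to compound 4 (1.34 log units; beyond the scatter). The estimate for compound 4 is 100 nM, ranging from 5 nM to 2500 nM.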

Compound 4, half-maximal inhibitory concentration: 22 nM
Beside the measured number, compound 4's estimate is 4.5-fold (0.66 log units) above it, and the stated range covers the measured number.
By their numbers in this assay, from the lowest: compound 2; then compound 4; then compound 1; then compound 3.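

In this assay, a further rearrangement of the same atoms on the amide-type nitrogen gives a 100-fold lower number from compound 3 to compound 4 (2.00 log units; beyond the scatter) and also a 31-fold higher number from compound 2 to compound 4 (1.50 log units; beyond the scatter) in this series, so all three isomeric groups now stand apart beyond the scatter. Against the group of compound 1, with three hetero atoms in its five-membered ring, the change gives only a 5.5-fold lower number from compound 1 to compound 4 (0.74 log units; beyond the scatter) as a modest gain, and compound 3 goes against this direction.

As far as these compounds go, whether a phenyl group on the amide-type nitrogen would keep any of this potency remains open. Nothing given here explains why these arrangements differ.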